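Moving the Pyridine Nitrogen in a Quinone Oxidoreductase Inhibitor

The source may hold more compounds than are shown below. What is called first, only, known or untested is meant among the compounds shown, and "the series" means these compounds.

Measured compounds in an assay on isolated protein for inhibition of sulfide:quinone oxidoreductase, mitochondrial (Homo sapiens); a lower number here means a stronger inhibitor, a higher number a weaker inhibitor:
- compound 1, `COc1ccc(-c2cc(-c3ccc(F)cc3)c(C#N)c(OC)n2)cc1`: compound 1 gives 1360 nM
- compound 2, `COc1cccc(-c2cc(-c3ccc(F)cc3)c(C#N)c(OC)n2)c1`: compound 2 gives 108 nM
- compound 3, `COc1nc(-c2cccnc2)cc(-c2ccc(F)cc2)c1C#N`: compound 3 gives 213 nM

Compound 3 stands second highest of the three numbers; its nearest neighbour is compound 2, and the step between them, a 2.0-fold higher number from compound 2 to compound 3 (0.29 log units; within the scatter), is within the scatter, while against compound 1 the step of a 6.4-fold lower number from compound 1 to compound 3 (0.81 log units; beyond the scatter) is beyond it. Compound 4, `COc1nc(-c2ccncc2)cc(-c2ccc(F)cc2)c1C#N`, has not been measured. It differs from compound 3 in one place: pyridin-4-yl in place of pyridin-3-yl on an aromatic carbon. The two compounds have the same atoms, joined differently.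

Among the measured compounds shown here, no measured step changes a pyridine ring in this way, so only indirect evidence bears on it. The step of a 13-fold lower number from compound 1 to compound 2 (1.10 log units; beyond the scatter) shows that shifting a substituent around the aryl ring on the shared core can change the number a lot, and a 6.4-fold lower number from compound 1 to compound 3 (0.81 log units; beyond the scatter) shows that the aryl ring itself matters. Since the direction cannot be read from these steps, a modest change in either direction is expected for compound 4, with a 1.9-fold higher number from compound 3 to compound 4 (0.27 log units; within the scatter) as the central guess. Compound 4 is therefore estimated at 400 nM, with a range from 120 nM to 1500 nM.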

Compound 4, half-maximal inhibitory concentration: 17400 nM
Beside the measured number, compound 4's estimate is 44-fold (1.64 log units) below it; the whole stated range lies below it.
By their numbers in this assay, from the lowest: compounds 2 and 3 (each within the scatter of the next); then compound 1; then compound 4.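

In this assay, the location of a single ring nitrogen proves decisive at this position: with the same atoms joined differently, the result is an 82-fold higher number from compound 3 to compound 4 (1.91 log units; beyond the scatter). A pyridine ring here therefore does not guarantee a low number, since compound 3 and compound 4 both carry one and still lie far apart. Among the compounds shown here, the pyridin-4-yl compound also falls well behind both methoxyphenyl compounds, with a 160-fold higher number from compound 2 to compound 4 (2.21 log units; beyond the scatter) and a 13-fold higher number from compound 1 to compound 4 (1.11 log units; beyond the scatter), so the aryl ring at this position can raise the number even further than the earlier compounds suggested.

Still open, on these data alone, is how a pyridin-2-yl ring would fare here, and whether an amine or a carboxylic acid on the ring would shift the number. Nothing shown offers a reason for this sharp dependence on where the nitrogen sits.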